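Replacing trifluoromethoxy with methoxy: what compound 4 may show

The source may hold more compounds than are shown below. What is called first, only, known or untested is meant among the compounds shown, and "the series" means these compounds.

Measured in a functional assay on NCI-H460 cells (Homo sapiens) for inhibition, read by MTT assay, with a stated time of 24 h, tested at 100 ug/mL; a higher number here means more inhibition of growth at the concentration tested, a lower number less inhibition of growth:
- compound 1 `O=C(CCCCC(S)CCS)Nc1ccccc1`: 25.4%
- compound 2 `O=C(CCCCC(S)CCS)Nc1ccc(Cl)cc1`: 40.9%
- compound 3 `O=C(CCCCC(S)CCS)Nc1ccc(OC(F)(F)F)cc1`: 65.1%

Compound 3 stands highest of the three in this assay, clear of the other two by more than the scatter. Compound 4 `COc1ccc(NC(=O)CCCCC(S)CCS)cc1` differs from it in one group: methyl in place of trifluoromethyl on an oxygen on an aromatic ring. This puts methyl in place of trifluoromethyl on an oxygen on an aromatic ring, turning trifluoromethoxy into methoxy. For the measured compounds named here, no measured step makes this exact change. Both other groups tested sit lower, however: a number 39.7 percentage points higher from compound 1 to compound 3 (beyond the scatter) is a large step, and a number 24.2 percentage points higher from compound 2 to compound 3 (beyond the scatter) is a modest one. A fall beyond the scatter is therefore expected, estimated as a number 29.1 percentage points lower from compound 3 to compound 4 (beyond the scatter). Compound 4 is expected at 36%, with an estimated range of 20% to 52%.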

Compound 4, percent growth inhibition at one concentration: 23.5%
Beside the measured number, compound 4's estimate is 12.5 percentage points above it; the range from low to high includes it.
By their numbers in this assay, from the lowest: compounds 4 and 1 (each within the scatter of the next); then compound 2; then compound 3.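

Within this assay, the oxygen on the aromatic ring does not hold the gain by itself: methyl in place of trifluoromethyl gives a number 41.6 percentage points lower from compound 3 to compound 4 (beyond the scatter) and gives up all of it. Methoxy in place of chloro gives a number 17.4 percentage points lower from compound 2 to compound 4 (beyond the scatter) as well, while methoxy in place of hydrogen gives a number 1.9 percentage points lower from compound 1 to compound 4 (within the scatter) and so compound 1 and compound 4 cannot be told apart here. The compounds shown leave open whether trifluoromethyl set directly on the aromatic carbon would read as trifluoromethoxy does, and how an amine or a carboxylic acid would read at this place. No evidence at hand bears on this result.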